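The source may report more compounds than this note shows. Statements on the series, on what has been measured and on what is new or still open speak of the compounds shown alone.

Working notes on the series. In an ADME assay on A549 cells (Homo sapiens) for cytotoxicity, read by MTT assay, with a stated time of 48 h (on this read-out higher numbers stand for weaker inhibition of growth and lower numbers for stronger inhibition of growth), compound 1 `O=C(/C=C\c1ccccc1)N1N=C(c2ccncc2)OC1c1c[nH]c2ccccc12` gives > 30 ug/mL, which is a limit of the assay rather than a number. Compound 2 `O=C(/C=C\c1cccc(O)c1)N1N=C(c2ccncc2)OC1c1c[nH]c2ccccc12` gives > 30 ug/mL in this assay, again a limit. Compound 3 `COc1ccc(/C=C\C(=O)N2N=C(c3ccncc3)OC2c2c[nH]c3ccccc23)cc1` likewise sits at a limit, > 30 ug/mL. Compound 2 therefore stands where every measured member of the series stands, at the limit of > 30 ug/mL in this assay, at which 3 of the 3 values shown sit, and no number places it higher or lower than compound 1 or compound 3.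

The steps among the measured compounds are a step that the two limits leave unreadable from compound 1 to compound 2, a step that the two limits leave unreadable from compound 1 to compound 3 and a step that the two limits leave unreadable from compound 2 to compound 3. None of the three has a readable size, so exchanging the group on the double-bonded chain carbon has so far left no measurable trace in this assay.

Compound 4 `O=C(/C=C\c1ccccc1Cl)N1N=C(c2ccncc2)OC1c1c[nH]c2ccccc12` differs from compound 2 in one place: 2-chlorophenyl in place of 3-hydroxyphenyl on a double-bonded chain carbon bound to a double-bonded chain carbon. Among the compounds with values here, the steps that bear on this change are the three unreadable ones, since each also exchanges the group on the same chain carbon; they give neither size nor direction. The step from compound 2 to compound 4 is thus expected to be a step that the limit leaves unreadable from compound 2 to compound 4, that is, nothing beyond the scatter and most probably another limit. Compound 4 is expected to give 45 ug/mL in this assay, with a range from 20 ug/mL to 100 ug/mL.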

Compound 4, concentration for 50% growth inhibition: > 30 ug/mL
Compound 4: only a limit was reported; the forecaster's own chance of this, stated with the estimate: 80%; the middle value lies beyond the limit too.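

No new step can be read: compound 4 gives a limit rather than a number, so its steps from compound 1, compound 2 and compound 3 in this assay all stay unreadable, and the series stands at: the limit of > 30 ug/mL in this assay, at which 4 of the 4 values shown sit.

The compounds shown leave open whether any group on the double-bonded chain carbon gives a readable number in this assay.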